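The source may hold more compounds than are shown below. What is called first, only, known or untested is meant among the compounds shown, and "the series" means these compounds.

compound 1 `COc1ccccc1-c1ccc(CNc2nc(NC3CCC(N)CC3)nc3c2ncn3C2CCCC2)cc1` gives 303 nM
compound 2 `NC1CCC(Nc2nc(NCc3ccc(-n4cccn4)cc3)c3ncn(C4CCCC4)c3n2)CC1` gives 139 nM

Among the measured compounds shown here, both numbers come from a functional assay on MCF7 cells (Homo sapiens) for inhibition, with a stated time of 72 h (a higher number here means a weaker inhibitor, a lower number a stronger inhibitor), and are the only measurements so far. Compound 2 holds the lower number of the two. For the measured compounds named here, the only measured step is a 2.2-fold lower number from compound 1 to compound 2 (0.34 log units; beyond the scatter) with 1H-pyrazol-1-yl in place of 2-methoxyphenyl on an aromatic carbon. That step is modest, though beyond the scatter.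

Next comes compound 3 `NC1CCC(Nc2nc(NCc3ccc(-c4ccccc4O)cc3)c3ncn(C4CCCC4)c3n2)CC1` with 2-hydroxyphenyl in place of 1H-pyrazol-1-yl on an aromatic carbon. The entering 2-hydroxyphenyl is closer in kind to the 2-methoxyphenyl of compound 1 than to the 1H-pyrazol-1-yl of compound 2. Going by the values given here, the one measured guide is therefore the step of a 2.2-fold lower number from compound 1 to compound 2 (0.34 log units; beyond the scatter) read in reverse, and it is a single step with no measured hydroxyl example behind it. A modest rise in the number in this assay is expected, possibly not clearing the scatter. The expected move is a 1.5-fold higher number from compound 2 to compound 3 (0.18 log units; within the scatter) on this reading. Compound 3 is estimated at 210 nM in an expected range from 80 nM to 500 nM as a working figure.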

Compound 3, half-maximal inhibitory concentration: 2910 nM
Estimate against measurement, compound 3: 14-fold (1.14 log units) below; the whole stated range lies below it.
By their numbers in this assay, from the lowest: compound 2; then compound 1; then compound 3.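

In this assay, hydrogen in place of methyl on an oxygen on an aromatic ring gives a 9.6-fold higher number from compound 1 to compound 3 (0.98 log units; beyond the scatter), so the two oxygen-bearing aryl groups are not interchangeable at this position, and what sits on that oxygen alone is enough to move the number well beyond the scatter. Among the compounds shown here, with 2-hydroxyphenyl in place of 1H-pyrazol-1-yl, the step is a 21-fold higher number from compound 2 to compound 3 (1.32 log units; beyond the scatter), the largest of the three steps, and it shows that this site, on an aromatic carbon para to a large group, responds far more widely than the first pair of compounds suggested. No measurement here bears on the origin of either step, and the result stands as an observation only.

As far as these compounds go, what stays open is whether the high number of compound 3 belongs to the free hydroxyl specifically, since an unsubstituted phenyl, a primary amine or a carboxylic acid at the same place would help separate that oxygen from the aryl ring carrying it. A longer alkoxy group in place of methoxy would also show whether the number keeps changing as the group on that oxygen grows.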